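Swapping a meta chloro for fluoro on a rhodanine-type scaffold

A few compounds are considered here, and "the series" means these few. Any claim that something is new, unique, unknown or untested is made for them only; others in the source may bear on it.

Of the compounds shown here, three sharing one core have been measured so far. Compound 1 `O=C1NC(=S)/C(=C/c2cc(Cl)cc(Cl)c2Cl)S1` gives 22.8% in a functional assay on HEp-2 cells (Homo sapiens) for cytotoxicity, read by MTT assay, with a stated time of 72 h, tested at 5 ug/mL; on this read-out higher numbers stand for more inhibition of growth at the one concentration tested and lower numbers for less inhibition of growth. Compound 2 `O=C1NC(=S)/C(=C/c2ccccc2Br)S1` gives 16.2% in this assay, and compound 3 `O=C1NC(=S)/C(=C/c2cccc(Cl)c2)S1` gives 17.6% in this assay. The number for compound 3 is neither the highest nor the lowest of the three, but the gaps to compound 2 and to compound 1 both lie within the scatter, so no real ordering can be read from them.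

Compound 4 `O=C1NC(=S)/C(=C/c2cccc(F)c2)S1` differs from compound 3 by fluoro in place of chloro on an aromatic carbon. Among the compounds with values here, no pair among the measured compounds differs in exactly one place, so there is no directly comparable step to lean on. Because compound 3 gives 17.6% and all three numbers cluster closely, the change is expected to shift the result little, if at all, beyond the scatter, perhaps slightly downward. Compound 4 is therefore estimated at 15% in this assay, within a range from 5% to 28%. The expected step from compound 3 to compound 4 is a number 2.6 percentage points lower from compound 3 to compound 4 (within the scatter).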

Compound 4, percent growth inhibition at one concentration: 19.8%
For compound 4 the middle estimate is 4.8 percentage points below the measured one; low and high end bracket the measured number.
By their numbers in this assay, from the lowest: compounds 2, 3, 4 and 1 (each within the scatter of the next).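

Within the data shown here, this is the first pair that differs in exactly one place: in this assay, fluoro in place of chloro on an aromatic carbon gives a number 2.2 percentage points higher from compound 3 to compound 4 (within the scatter). At this position, meta to a group of 8 heavy atoms, the two halogens therefore cannot be told apart by percent growth inhibition at the one concentration tested. Nothing available explains this result.

Going by these compounds, what remains open is how this position responds to a group other than a halogen, such as an amine, a carboxylic acid or a longer chain. The compounds shown also leave open whether compound 3 and compound 4 would still read alike at other concentrations, where a full dose-response comparison could show more.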